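Quinone in place of dimethoxyphenyl on a pyrazole sulfonamide

This account rests on a few compounds, and the source may have more. Where it says the series, first, only, none or still open, it means among the compounds named here.

Compound 2 `COc1ccc(OC)c(-c2cc(-c3ccccc3)nn2-c2ccc(S(=O)(=O)NC(C)=O)cc2)c1` gives 18100 nM in a functional assay on cells (Cancer cell lines, Homo sapiens) for cytotoxicity, read by sulforhodamine B assay, with a stated time of 48 h (a higher number here means a weaker inhibitor of growth, a lower number a stronger inhibitor of growth), the highest of the two numbers; compound 1 `COc1ccc(OC)c(-c2cc(-c3ccccc3)nn2-c2ccc(S(N)(=O)=O)cc2)c1` gives 15000 nM, and a 1.2-fold higher number from compound 1 to compound 2 (0.08 log units; within the scatter). Compound 3 `CC(=O)NS(=O)(=O)c1ccc(-n2nc(-c3ccccc3)cc2C2=CC(=O)C=CC2=O)cc1` differs from compound 2 by a group of 8 heavy atoms (6 carbon, 2 oxygen; one six-membered non-aromatic ring of carbon only) in place of a group of 10 heavy atoms (8 carbon, 2 oxygen; one six-membered aromatic ring of carbon only), on an aromatic carbon. Among the measured compounds shown here, no measured step touches this part of the core, so nothing here shows how large a change to expect. Compound 3 is therefore estimated near compound 2, at 8000 nM, with a wide range from 1000 nM to 40000 nM, which means an expected step of a 2.3-fold lower number from compound 2 to compound 3 (0.35 log units; beyond the scatter).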

Compound 3, concentration for 50% growth inhibition: 100000 nM
Beside the measured number, compound 3's estimate is 13-fold (1.10 log units) below it; measured number outside the range, above it.
By their numbers in this assay, from the lowest: compounds 1 and 2 (each within the scatter of the next); then compound 3.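

In this assay, putting the quinone in place of 2,5-dimethoxyphenyl gives a 5.5-fold higher number from compound 2 to compound 3 (0.74 log units; beyond the scatter) and so weakens growth inhibition. The acetyl change on the sulfonamide nitrogen gave only a 1.2-fold higher number from compound 1 to compound 2 (0.08 log units; within the scatter) and stayed within the scatter, whereas this aromatic carbon of the five-membered ring responds clearly to what it carries. Nothing measured here accounts for the loss. Going by these compounds, whether a 2,5-dihydroxyphenyl group or a single methoxy group on the phenyl ring would keep the level of compound 2 stays open. The same holds for the quinone paired with the free sulfonamide.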